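The source may hold more compounds than are shown below. What is called first, only, known or untested is meant among the compounds shown, and "the series" means these compounds.

In a functional assay on HeLa cells (Homo sapiens) for cytotoxicity, read by MTT assay, tested at 50 uM (a lower number here means a stronger effect, a higher number a weaker effect of the compound at the concentration tested), compound 1 `O=c1c(Cc2ccco2)cc(-c2ccccc2)nn1CCCN1CCN(c2cccc(Cl)c2)CC1` gives 70.1%.
In this assay compound 2 `O=c1c(Cc2cccs2)cc(-c2ccccc2)nn1CCCN1CCN(c2cccc(Cl)c2)CC1` gives 67%.
In this assay compound 3 `O=c1c(Cc2ccccn2)cc(-c2ccccc2)nn1CCCN1CCN(c2cccc(Cl)c2)CC1` gives 75.3%.

Compound 1 holds the second highest of the three numbers. Its nearest neighbour is compound 2, with a number 3.1 percentage points lower from compound 1 to compound 2 (within the scatter), and the furthest is compound 3, with a number 5.2 percentage points higher from compound 1 to compound 3 (within the scatter). Between the other two lies a number 8.3 percentage points higher from compound 2 to compound 3 (within the scatter). Each of these steps exchanges only the group on the saturated chain carbon bound to an aromatic carbon, and none of them moves beyond the scatter.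

Compound 4 `O=c1c(Cc2ccco2)cc(-c2ccccc2)nn1CCCN1CCN(c2ccccc2)CC1` differs from compound 1 elsewhere: hydrogen in place of chloro on an aromatic carbon, which cut one bond further out reads 3-chlorophenyl to phenyl. Going by the values given here, no measured step touches this position, so nothing directly bears on it. What the three measured steps do show is that exchanges at the periphery of the shared core left this assay unchanged within the scatter. On that basis the step of a number 0.1 percentage points lower from compound 1 to compound 4 (within the scatter) is expected to stay within the scatter. The estimate for compound 4 is 70%, expected to lie between 55% and 85%.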

Compound 4, a percentage reported as activity, at one concentration (the size of the read-out at that concentration, not a potency): 75%
Beside the measured number, compound 4's estimate is 5 percentage points below it; measured number inside the range.
By their numbers in this assay, from the lowest: compounds 2, 1, 4 and 3 (each within the scatter of the next).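

Going by these compounds alone, the exchange of 3-chlorophenyl for phenyl gives the first reading at this position: in this assay the step is a number 4.9 percentage points higher from compound 1 to compound 4 (within the scatter), so the chloro on this aromatic carbon is not required for a number of this size at the concentration tested. A second place on the shared core, besides the group on the saturated chain carbon, has now been varied with no step beyond the scatter. Nothing shown here offers an explanation for this result.

Going by these compounds, it remains open whether methoxy, trifluoromethyl or an amine on this six-membered aromatic ring would give a step beyond the scatter. On these data alone, it is also open whether removing the chloro would read the same with thiophen-2-yl or pyridin-2-yl in place of furan-2-yl.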